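Phenoxy in place of ethyl on a sulfonamide series

The source may report more compounds than this note shows. Statements on the series, on what has been measured and on what is new or still open speak of the compounds shown alone.

Compound 1 `Cc1ccccc1NS(=O)(=O)c1cccc(CCCCCCNC(=O)/C=C/c2cccnc2)c1`: 2.9 nM
Compound 2 `CCc1ccc(NS(=O)(=O)c2cccc(CCCCCCNC(=O)/C=C/c3cccnc3)c2)cc1`: 40.1 nM
Compound 3 `O=C(/C=C/c1cccnc1)NCCCCCCc1cccc(S(=O)(=O)Nc2ccc(F)c(Cl)c2)c1`: 150 nM

In a functional assay on DU-145 cells (Homo sapiens) for inhibition, read by CCK-8 assay, with a stated time of 72 h (a higher number here means a weaker inhibitor, a lower number a stronger inhibitor), compound 2 gives 40.1 nM, the second highest of the three numbers, so it sits between the other two compounds. Compound 4 `O=C(/C=C/c1cccnc1)NCCCCCCc1cccc(S(=O)(=O)Nc2ccc(Oc3ccccc3)cc2)c1` differs from compound 2 in one place: phenoxy in place of ethyl on an aromatic carbon.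

Among the compounds with values here, no measured step makes this exact change, so the evidence is indirect. It comes from swaps of the group on the sulfonamide nitrogen. Two of these were large, a 14-fold higher number from compound 1 to compound 2 (1.14 log units; beyond the scatter) and a 52-fold higher number from compound 1 to compound 3 (1.71 log units; beyond the scatter). The third was modest, a 3.7-fold higher number from compound 2 to compound 3 (0.57 log units; beyond the scatter). Within the data shown here, that last step is the only one that starts from compound 2, and it is the closest guide, though three compounds make a thin basis. A modest rise in this assay is expected, a 2.2-fold higher number from compound 2 to compound 4 (0.35 log units; beyond the scatter). Compound 4 is estimated at 90 nM, with an expected range of 20 nM to 350 nM.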

Compound 4, half-maximal inhibitory concentration: 50.9 nM
The estimate for compound 4 lay 1.8-fold (0.25 log units) above the measured number; measured number inside the range.
By their numbers in this assay, from the lowest: compound 1; then compounds 2 and 4 (each within the scatter of the next); then compound 3.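

In this assay, the swap of ethyl for phenoxy on an aromatic carbon, para to a large group, gives a 1.3-fold higher number from compound 2 to compound 4 (0.10 log units; within the scatter). Unlike the earlier steps, each of which replaced the whole group on the sulfonamide nitrogen and fell beyond the scatter, this change at a single place leaves compound 2 and compound 4 indistinguishable, even though the entering group brings 7 heavy atoms and a six-membered aromatic ring in place of 2 heavy atoms and no ring. The data shown offer no measured explanation for this result.

On these data alone, whether this position would accommodate an amine or a carboxylic acid as readily as phenoxy remains open. So does whether a benzyloxy group, with its longer link to the outer ring, would leave the number within the scatter of compound 2.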